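Hydroxy in Place of Hydrogen: Expected Tolerance of Compound 3

A few compounds are considered here, and "the series" means these few. Any claim that something is new, unique, unknown or untested is made for them only; others in the source may bear on it.

Compound 1, `O=c1nc(NO)ccn1[C@@H]1CS[C@H](CO)O1`: 1450000 nM
Compound 2, `Cc1cn([C@@H]2CC[C@H](CO)O2)c(=O)nc1N`: 950000 nM

Both were tested in an ADME assay on HL-60 cells (Homo sapiens) for cytotoxicity, read by MTT assay, with a stated time of 3 days; a higher number here means that more compound is tolerated, a lower number that less compound is tolerated. Compound 2 gives 950000 nM and compound 1 gives 1450000 nM; the two values lie within the usual scatter of each other, so compound 2 does not stand apart. Compound 3, `Cc1cn([C@@H]2C[C@@H](O)[C@H](CO)O2)c(=O)nc1N`, differs from compound 2 by hydroxy in place of hydrogen on a saturated ring carbon. Among the compounds with values here, no measured pair shows a step of this kind, so its size is not known from these data; in this assay a step no larger than the scatter is expected, in either direction. Compound 3 is therefore estimated at 650000 nM, with a range from 150000 nM to 2500000 nM. That corresponds to an expected step of a 1.5-fold lower number from compound 2 to compound 3 (0.16 log units; within the scatter).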

Compound 3, half-maximal cytotoxic concentration: > 2000000 nM
Compound 3: only a limit was reported (the forecaster's own chance of this, stated with the estimate: 25%); at least 3.0-fold (0.48 log units) between middle value and limit.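

In this assay, hydroxy in place of hydrogen on this saturated ring carbon, next to the ring atom that bears a hydroxymethyl group, gives an at least 2.1-fold higher number from compound 2 to compound 3 (0.32 log units; beyond the scatter). Compound 3 gives > 2000000 nM, which is a limit and not a number. So at this position the change allows more compound to be tolerated, not less, and the true size of the step stays unknown, resting as it does on a limit: the limit of > 2000000 nM in this assay, at which 1 of the 3 values shown sits.

The compounds shown leave open how an amine or a methoxy group on this same ring carbon would fare. They also leave open whether hydroxy on another ring carbon would give a similar step.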